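Swapping Butoxy for Propargyloxy on a Shared Core

The source may report more compounds than this note shows. Statements on the series, on what has been measured and on what is new or still open speak of the compounds shown alone.

- compound 1 `COc1ccc(C(=O)Nc2cc3ccc(OC4CCN(C)CC4)c(C)c3oc2=O)cc1CC=C(C)C`: 1580 nM
- compound 2 `CCCCOc1ccc(C(=O)Nc2cc3ccc(OC4CCN(C)CC4)c(C)c3oc2=O)cc1CC=C(C)C`: 1440 nM

These two compounds were tested in a functional assay on MCF7 cells (Homo sapiens) for antiproliferative activity; a lower number here means a stronger inhibitor, a higher number a weaker inhibitor. Compound 2, at 1440 nM, lies within the scatter of compound 1, at 1580 nM, so the two cannot be ranked against each other.

The next compound, compound 3 `C#CCOc1ccc(C(=O)Nc2cc3ccc(OC4CCN(C)CC4)c(C)c3oc2=O)cc1CC=C(C)C`, keeps the shared core and changes only the chain, turning butoxy into propargyloxy: ethynyl in place of propyl on a saturated chain carbon bound to an oxygen on an aromatic ring. In words, this puts ethynyl in place of propyl on a saturated chain carbon bound to an oxygen on an aromatic ring.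

For the measured compounds named here, only one measured step bears on this change. It put propyl in place of hydrogen at the same place and gave a 1.1-fold lower number from compound 1 to compound 2 (0.04 log units; within the scatter). Going by the values given here, that single step is thin evidence, and no measured compound has a triple bond, so the new group remains untested.

The estimated change is a 1.0-fold higher number from compound 2 to compound 3 (0.02 log units; within the scatter), meaning that no step beyond the scatter is expected in this assay. For compound 3 the expected value is 1500 nM, with an estimated range of 750 nM to 3000 nM.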

Compound 3, half-maximal inhibitory concentration: 1120 nM
The estimate for compound 3 lay 1.3-fold (0.13 log units) above the measured number; the measured number falls inside the stated range.
By their numbers in this assay, from the lowest: compounds 3, 2 and 1 (each within the scatter of the next).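

In this assay, ethynyl in place of propyl on a saturated chain carbon bound to an oxygen on an aromatic ring gives a 1.3-fold lower number from compound 2 to compound 3 (0.11 log units; within the scatter) and ethynyl in place of hydrogen at that same place gives a 1.4-fold lower number from compound 1 to compound 3 (0.15 log units; within the scatter) in the same reading. The earlier pair showed only that adding a saturated propyl there left the number within the scatter, while this result extends that finding to a group with a triple bond, so all three compounds stay within the scatter of the next and cannot be ranked in this series. Nothing else in the data explains why the numbers stay so close.

Going by these compounds, whether this position would accept any group equally remains open, since an amine, a carboxylic acid or a chain longer than butoxy at this place could still move the number beyond the scatter. On these data alone, all three compounds also keep the rest of the structure fixed and are read in this assay alone, so it is unknown whether the same pattern would hold on a changed core or in another assay.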